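The source may hold more compounds than are shown below. What is called first, only, known or untested is meant among the compounds shown, and "the series" means these compounds.

Working notes on the series: in an ADME assay on MT4 cells (Homo sapiens) for cytotoxicity, read by MTT assay, with a stated time of 4 days (a lower number here means that less compound is tolerated, a higher number that more compound is tolerated), compound 1 (`C/C(=N\NC(=O)COc1cccc2ccccc12)c1ccccc1`) gives 105 ug/mL and compound 2 (`O=C(COc1cccc2ccccc12)N/N=C/C=C/c1ccccc1`) gives 82.7 ug/mL. These two numbers lie within the scatter of each other, so compound 1 stands level with its only measured comparator. Compound 3 (`C/C(=N\NC(=O)COc1cccc2ccccc12)c1ccc(O)cc1`) has hydroxy in place of hydrogen on an aromatic carbon, phenyl to 4-hydroxyphenyl (hydroxy in place of hydrogen on an aromatic carbon). Among the compounds with values here, the series holds no measured step of this kind, so no shift beyond the scatter is expected in this assay, and no direction is favoured (expected step: a 1.2-fold lower number from compound 1 to compound 3 (0.07 log units; within the scatter)). The estimated value for compound 3 is 90 ug/mL (expected range: 35 ug/mL to 200 ug/mL).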

Compound 3, half-maximal cytotoxic concentration: 68.8 ug/mL
Compound 3: the middle estimate sits 1.3-fold (0.12 log units) above what was measured, within the range that was stated.
By their numbers in this assay, from the lowest: compounds 3, 2 and 1 (each within the scatter of the next).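

In this assay, the change from phenyl to 4-hydroxyphenyl gives a 1.5-fold lower number from compound 1 to compound 3 (0.18 log units; within the scatter), the first step read at this position of the series. A single hydroxy on this aromatic carbon, para to a large group, therefore does not shift the number beyond the scatter. Nothing available gives a reason for the size of this step. On these data alone, whether an amine, a carboxylic acid or a methoxy group at this place would give a step beyond the scatter stays open. So does the effect of hydroxy elsewhere on the same ring.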